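The compounds below may be only part of what the source reports. "The series", "measured", "known", "first", "only" and "open" are said of these compounds alone.

Measured compounds:

- Compound 1, `Oc1ccc(-c2cc(-c3ccccc3)cc(-c3cccs3)n2)cc1`: 12500 nM in a functional assay on HCT-15 cells (Homo sapiens) for cytotoxicity, read by ELISA, with a stated time of 2 days; on this read-out higher numbers stand for weaker inhibition and lower numbers for stronger inhibition
- Compound 2, `Oc1ccc(-c2cc(-c3ccccc3)cc(-c3ccsc3)n2)cc1`: in this assay compound 2 gives 1100 nM
- Compound 3, `Oc1cccc(-c2cc(-c3ccccc3)nc(-c3cccs3)c2)c1`: in this assay compound 3 gives 14100 nM

Compound 1 and compound 2 share a core and differ in one place. The change is thiophen-3-yl in place of thiophen-2-yl on an aromatic carbon. That change made a large step in this assay: an 11-fold lower number from compound 1 to compound 2 (1.06 log units; beyond the scatter).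

Compound 3 carries the hydroxyl on a different position of its phenyl ring than compound 1, and its value in this assay lies within the scatter of that of compound 1. The difference between the two cores is not broken down here.

Compound 4, `Oc1cccc(-c2cc(-c3ccccc3)nc(-c3ccsc3)c2)c1`, has not yet been measured. It relates to compound 3 as compound 2 relates to compound 1, by the same kind of change: thiophen-3-yl in place of thiophen-2-yl on an aromatic carbon. Around the place, compound 3 and compound 4 carry a 3-hydroxyphenyl group where compound 1 and compound 2 carry a 4-hydroxyphenyl group, so the surroundings are not identical.

Because the same kind of change gave an 11-fold lower number from compound 1 to compound 2 (1.06 log units; beyond the scatter) from a starting point close to that of compound 3, a step of similar direction is expected for compound 4, estimated as a 7.8-fold lower number from compound 3 to compound 4 (0.89 log units; beyond the scatter). This rests on a single earlier example, so the range is kept wide. For compound 4 in this assay the expected value is 1800 nM, estimated to lie between 500 nM and 7000 nM.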

Compound 4, half-maximal inhibitory concentration: 24600 nM
For compound 4 the middle estimate is 14-fold (1.14 log units) below the measured one; measured number outside the range, above it.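

On the core of compound 3, the swap of thiophen-2-yl for thiophen-3-yl gives a 1.7-fold higher number from compound 3 to compound 4 (0.24 log units; within the scatter) in this assay, so on this core the two thiophene attachments cannot be told apart. The swap therefore does not carry over from one core to the other, and what it does in this series depends on the core that carries it, even though compound 1 and compound 3 start from values within the scatter of each other: the same change on two cores in this assay, an 11-fold lower number (1.06 log units; beyond the scatter) from compound 1 to compound 2 and a 1.7-fold higher number (0.24 log units; within the scatter) from compound 3 to compound 4, 20-fold (1.30 log units) apart, beyond the scatter of two such steps

Going by these compounds alone, with only one pair on each core, and with the difference between the two cores not broken down, this does not show which feature of the core decides the outcome, nor what the swap would do on a third core.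

The compounds shown all keep a hydroxyl on one phenyl ring and an unsubstituted phenyl on the other, so it remains open whether the swap would behave the same way with an amine or a methoxy group in place of that hydroxyl. Also open, on these data alone, is what a furan in place of the thiophene would do on either core, and whether the pattern of these four compounds would hold in any other cell line.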